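The source may hold more compounds than are shown below. What is called first, only, known or untested is meant among the compounds shown, and "the series" means these compounds.

Measured so far in an assay on CHO cells, read by calcium flux; a lower number here means a stronger inhibitor, a higher number a weaker inhibitor:

- compound 1, `O=C(Nc1ccc(C(F)(F)F)cc1)c1csc(Cc2c(Cl)cccc2Cl)n1`: 140 nM
- compound 2, `O=C(Nc1ccc(C(F)(F)F)cc1)c1csc(Oc2c(Cl)cccc2Cl)n1`: 870 nM

Compound 2 gives the higher of the two numbers in this assay; the step of a 6.2-fold higher number from compound 1 to compound 2 (0.79 log units; beyond the scatter) lies beyond the scatter. Compound 3, `O=C(Nc1ccc(C(F)(F)F)cc1)c1csc(Nc2c(Cl)cccc2Cl)n1`, is not yet measured. It differs from compound 2 in one place: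

(2,6-dichlorophenyl)amino in place of 2,6-dichlorophenoxy on an aromatic carbon

Going by the values given here, the only measured step that bears on this change is the one from compound 1 to compound 2, also a swap of the group joining the 2,6-dichlorophenyl ring to the shared core, and it was modest in size. The present swap, oxygen for nitrogen in that link, is of the same kind but smaller than the earlier one; with a single reference step the direction is uncertain. A step of roughly a 1.7-fold lower number from compound 2 to compound 3 (0.24 log units; within the scatter) is expected, toward a somewhat lower number but possibly within the scatter. Compound 3 is therefore estimated at 500 nM, with a range from 150 nM to 2000 nM.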

Compound 3, half-maximal inhibitory concentration: 51 nM
Beside the measured number, compound 3's estimate is 9.8-fold (0.99 log units) above it; measured number below the stated range.
By their numbers in this assay, from the lowest: compound 3; then compound 1; then compound 2.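

In this assay, the group joining the 2,6-dichlorophenyl ring to the shared core has a large effect even with the heavy-atom count unchanged: the swap of 2,6-dichlorophenoxy for (2,6-dichlorophenyl)amino gives a 17-fold lower number from compound 2 to compound 3 (1.23 log units; beyond the scatter). The amino link also passes the benzyl link, with a 2.7-fold lower number from compound 1 to compound 3 (0.44 log units; beyond the scatter), so the order at this position, from the lowest number, is amino, benzyl, phenoxy. The entering group carries a hydrogen-bond donor that the leaving group lacks, but no available evidence bears on what lies behind these steps.

The compounds shown leave open whether the amino hydrogen matters, which a methylamino link in the same place would test. They also leave open whether the order holds with an unsubstituted phenyl ring in place of the 2,6-dichlorophenyl ring.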